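The source may report more compounds than this note shows. Statements on the series, on what has been measured and on what is new or still open speak of the compounds shown alone.

Working notes on the sulfonamide series. Going by the values given here, compound 2 `O=S(=O)(NCCCNCc1ccc(C(F)(F)F)cc1)c1cc(C(F)(F)F)cc(C(F)(F)F)c1` gives 2000 nM in a functional assay on Capan-2 cells (Homo sapiens) for inhibition, read by MTT assay, with a stated time of 72 h (on this read-out lower numbers stand for stronger inhibition of growth and higher numbers for weaker inhibition of growth), and stands lowest of the three numbers so far. Compound 1 `CC(C)(C)c1ccc(CNCCNS(=O)(=O)c2cc(C(F)(F)F)cc(C(F)(F)F)c2)cc1` gives 13000 nM and compound 3 `O=S(=O)(NCCNCc1cccc2ccccc12)c1cc(C(F)(F)F)cc(C(F)(F)F)c1` gives 21000 nM in this assay; both lie beyond the scatter from compound 2. Among the compounds with values here, the one measured step, a 1.6-fold higher number from compound 1 to compound 3 (0.21 log units; within the scatter), exchanges the aryl group on the saturated chain carbon bound to the amine nitrogen and falls within the scatter. Compound 4 `O=S(=O)(NCCCNCc1ccc(Br)cc1)c1cc(C(F)(F)F)cc(C(F)(F)F)c1` differs from compound 2 by bromo in place of trifluoromethyl on an aromatic carbon. Within the data shown here, no measured step covers an exchange on that aromatic carbon, and the only step at that end of the molecule was small, so in this assay the expected step is a 1.3-fold higher number from compound 2 to compound 4 (0.10 log units; within the scatter), nothing beyond the scatter. Compound 4 is estimated at 2500 nM, range 1000 nM to 6500 nM.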

Compound 4, concentration for 50% growth inhibition: 2000 nM
Compound 4: the middle estimate sits 1.3-fold (0.10 log units) above what was measured; the range from low to high includes it.
By their numbers in this assay, from the lowest: compounds 2 and 4 (each within the scatter of the next); then compounds 1 and 3 (each within the scatter of the next).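

Exchanging trifluoromethyl for bromo on the aromatic carbon para to a large group gives no change at the digits printed from compound 2 to compound 4 (within the scatter) in this assay. The earlier compounds shown here held no exchange at this position; here, one bromine atom stands in for the four heavy atoms of trifluoromethyl, and the growth-inhibition reading stays within the scatter. Nothing on hand bears on why these two groups read alike.

Still open, on these data alone, is whether an amine or a carboxylic acid on this aromatic carbon would leave the reading within the scatter. A longer chain carrying the 4-bromobenzyl group is also untested in the compounds shown here.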